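The compounds below may be only part of what the source reports. "The series", "measured", "known", "first", "only" and "open" are said of these compounds alone.

Three compounds of one shared core have been examined. Compound 1 `Cc1ccc(-c2nn(-c3ccccc3)cc2-c2nc3ccccc3n2C(=O)c2ccc(Cl)cc2)cc1` gives, in an ADME assay on HEK-293T cells (Homo sapiens) for cytotoxicity, read by MTT assay, with a stated time of 24 h (on this read-out lower numbers stand for higher toxicity in this test and higher numbers for lower toxicity in this test), a value of 216000 nM. Compound 2 `O=C(c1ccccc1)n1c(-c2cn(-c3ccccc3)nc2-c2ccc(C(F)(F)F)cc2)nc2ccccc21` gives in this assay a value of 168000 nM, and compound 3 `O=C(c1ccc(Cl)cc1)n1c(-c2cn(-c3ccccc3)nc2-c2ccc(F)cc2)nc2ccccc21` gives in this assay a value of 179000 nM. Within the data shown here, the three numbers lie close together: compound 3 stands second highest of the three, with compound 2 nearest and compound 1 furthest, both gaps within the scatter, as the single step of a 1.2-fold lower number from compound 1 to compound 3 (0.08 log units; within the scatter) also shows.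

Compound 4 `O=C(c1ccc(Cl)cc1)n1c(-c2cn(-c3ccccc3)nc2-c2ccc(C(F)(F)F)cc2)nc2ccccc21` differs from compound 3 in one place: trifluoromethyl in place of fluoro on an aromatic carbon. Among the measured compounds shown here, no measured step covers this exact change. Compound 2 carries the same trifluoromethyl group, and its value sits within the scatter of that of compound 3, which is the only pointer available. On that basis compound 4 is expected to show a 1.0-fold lower number from compound 3 to compound 4 (0.01 log units; within the scatter), with no step beyond the scatter. The estimated value for compound 4 in this assay is 175000 nM, within a range of 100000 nM to 300000 nM.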

Compound 4, half-maximal cytotoxic concentration: 181000 nM
Compound 4: middle estimate off by 1.0-fold (0.01 log units), on the low side; the range from low to high includes it.
By their numbers in this assay, from the lowest: compounds 2, 3, 4 and 1 (each within the scatter of the next).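

In this assay, trifluoromethyl in place of fluoro on an aromatic carbon, para to a large group, gives a 1.0-fold higher number from compound 3 to compound 4 (0.00 log units; within the scatter), and trifluoromethyl in place of methyl at that same position gives a 1.2-fold lower number from compound 1 to compound 4 (0.08 log units; within the scatter), so methyl, fluoro and trifluoromethyl can now be compared there with the rest of the structure held constant, and none of the steps leaves the scatter. The chloro group, previously unread as a single change, gives a 1.1-fold higher number from compound 2 to compound 4 (0.03 log units; within the scatter) when it stands in place of hydrogen on an aromatic carbon, again within the scatter. No measurement offered here accounts for these results.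

From the compounds shown here alone, whether an amine, a carboxylic acid or a longer chain at this position would also stay within the scatter remains open. So does whether any change to the shared core would do so.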